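Lengthening the Chain of Compound 2

The source may hold more compounds than are shown below. What is called first, only, known or untested is meant among the compounds shown, and "the series" means these compounds.

Two compounds have been examined in a functional assay on HepG2 cells (Homo sapiens) for cytotoxicity, with a stated time of 72 h; a lower number here means that less compound is needed, a higher number that more compound is needed for the effect. Compound 1, `C=C[C@@](C)(/C=C/c1ccc(OC)cc1)CCC=C(C)C`, is the methoxy-bearing member of the pair. In this assay compound 1 gives only a limit of the assay, > 52000 nM. Compound 2, `C=C[C@@](C)(/C=C/c1ccc(O)cc1)CCC=O`, carries a free phenol and a chain ending in a formyl group. In this assay compound 2 likewise gives only a limit, > 52000 nM. Among the measured compounds shown here, compound 2 therefore stands where every value so far stands: at the limit of > 52000 nM in this assay, at which 2 of the 2 values shown sit.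

Compound 3, `C=C[C@@](C)(/C=C/c1ccc(O)cc1)CC/C=C(\C)CO`, differs from compound 2 by one change: 2-(hydroxymethyl)prop-1-en-1-yl in place of formyl on a saturated chain carbon, three bonds along the chain from two double-bonded chain carbons. For the measured compounds named here, with both measured compounds sitting at a limit, no measured step is available to guide an expectation. The step from compound 2 to compound 3 is expected to be a step that the limit leaves unreadable from compound 2 to compound 3, that is, nothing beyond the usual scatter. Compound 3 is expected to give about 80000 nM, in a range from 30000 nM to 250000 nM, most probably again reported only as a limit.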

Compound 3, half-maximal effective concentration: > 52000 nM
Compound 3: no number, only a limit; the forecaster's own chance of this, stated with the estimate: 80%; the middle value lies beyond the limit too.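

No step can be read from compound 2 to compound 3, because both give only a limit, not a number: (the limit of > 52000 nM in this assay, at which 3 of the 3 values shown sit). The compounds shown leave open whether any change to the shared core would give a measurable value, and how formyl and 2-(hydroxymethyl)prop-1-en-1-yl truly compare.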